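A few compounds are considered here, and "the series" means these few. Any claim that something is new, unique, unknown or untested is made for them only; others in the source may bear on it.

Compound 1 `C=CCOc1c(Cl)cccc1C(=O)c1cccnc1` gives 100000 nM in a functional assay on HeLa cells (Homo sapiens) for cytotoxicity, read by sulforhodamine B assay, with a stated time of 48 h (a lower number here means a stronger inhibitor, a higher number a weaker inhibitor), and compound 2 `C=CCOc1ccc(Cl)cc1C(=O)c1cccnc1` gives 75000 nM there, so compound 2 stands within the scatter of compound 1. Compound 3 `C=CCOc1c(Cl)cc(Cl)cc1C(=O)c1cccnc1` follows from compound 2 through chloro in place of hydrogen on an aromatic carbon with chloro in place of hydrogen on an aromatic carbon, ortho to an allyloxy group. Compound 3 thus carries both chloro groups seen singly in compound 1 and compound 2. For the measured compounds named here, no measured step is available as a guide, so a modest move toward a lower number in this assay is expected, only slightly beyond the scatter. The estimated 2.1-fold lower number from compound 2 to compound 3 (0.33 log units; beyond the scatter) would be of that size. For compound 3 the estimate is 35000 nM with an expected range of 12000 nM to 100000 nM in this reading.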

Compound 3, half-maximal inhibitory concentration: 34000 nM
Estimate against measurement, compound 3: 1.0-fold (0.01 log units) above; the measured number falls inside the stated range.
By their numbers in this assay, from the lowest: compound 3; then compounds 2 and 1 (each within the scatter of the next).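

In this assay, for the compounds shown here, chloro in place of hydrogen on an aromatic carbon, ortho to an allyloxy group, gives the first step beyond the scatter, a 2.2-fold lower number from compound 2 to compound 3 (0.34 log units; beyond the scatter). The other chloro group of compound 3 also counts, with a 2.9-fold lower number from compound 1 to compound 3 (0.47 log units; beyond the scatter), whereas compound 1 and compound 2, each with one chloro group, stood within the scatter of each other. Nothing shown explains why the two chloro groups together give the lower number. Going by these compounds, it remains open whether a fluoro or methoxy group would match chloro at this position, and how a longer chain in place of allyloxy would read.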